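This account rests on a few compounds, and the source may have more. Where it says the series, first, only, none or still open, it means among the compounds named here.

Compound 1 `O=c1n(Cc2cn3ccc(Cl)cc3n2)c2cnccc2n1C1CC1` gives 22300 nM in an ADME assay on HEp-2 cells (Homo sapiens) for cytotoxicity, read by CCK-8 assay, with a stated time of 6 days; a lower number here means that less compound is tolerated, a higher number that more compound is tolerated. Compound 2 `N#Cc1c(Cn2c(=O)n(C3CC3)c3ccncc32)nc2cc(Cl)ccn12` gives 22500 nM in this assay, and a 1.0-fold higher number from compound 1 to compound 2 (0.00 log units; within the scatter). Compound 3 `O=C(CCc1c(Cn2c(=O)n(C3CC3)c3ccncc32)nc2cc(Cl)ccn12)NCCO` reaches only a limit of the assay in this assay, recorded as > 100000 nM, as noted in the limit of > 100000 nM in this assay, at which 1 of the 3 values shown sits. Accordingly an at least 4.4-fold higher number from compound 1 to compound 3 (0.65 log units; beyond the scatter) and an at least 4.4-fold higher number from compound 2 to compound 3 (0.64 log units; beyond the scatter), so compound 3 stands at the top of the measured range. Compound 4 `O=c1n(Cc2nc3cc(Cl)ccn3c2CNCCO)c2cnccc2n1C1CC1` differs from compound 3 by (2-hydroxyethyl)amino in place of ((2-hydroxyethyl)carbamoyl)methyl on a saturated chain carbon bound to an aromatic carbon. The two steps that bear on this change, from compound 1 and from compound 2 to compound 3, each added a chain carrying a hydroxyethyl group and both moved the number upward beyond the scatter; compound 4 keeps a hydroxyethyl tail, so the expected step in this assay is an at least 1.4-fold lower number from compound 3 to compound 4 (0.15 log units; that floor lies within the scatter), small or at most modest downward, with a fair chance of another limit. Compound 4 is expected to give 70000 nM, within 25000 nM to 200000 nM.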

Compound 4, half-maximal cytotoxic concentration: > 100000 nM
Compound 4: only a limit was reported; the forecaster's own chance of this, stated with the estimate: 45%; at least 1.4-fold (0.15 log units) between middle value and limit.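

In this assay, ((2-hydroxyethyl)amino)methyl on this aromatic carbon gives an at least 4.4-fold higher number from compound 1 to compound 4 (0.65 log units; beyond the scatter) in place of hydrogen, and an at least 4.4-fold higher number from compound 2 to compound 4 (0.64 log units; beyond the scatter) in place of cyano. The step between compound 3 and compound 4 cannot be read, as both values are limits. The carbamoyl-containing chain is therefore not the only chain at this position to reach the top of the range: the limit of > 100000 nM in this assay, at which 2 of the 4 values shown sit.

Going by these compounds, whether the hydroxyethyl end is needed for this rise stays open. A plain aminomethyl group or a carboxylic acid on the chain would test that, and compound 3 and compound 4 remain unranked.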